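The source may hold more compounds than are shown below. What is called first, only, known or untested is meant among the compounds shown, and "the series" means these compounds.

Going by the values given here, compound 3 `Cc1ccc(S(=O)(=O)N2C=CNC(=O)[C@H]2CC(=O)NC2CCCCC2C)cc1` gives 25.9 nM in an in vitro functional assay on cells for antagonist activity at B1 bradykinin receptor (Homo sapiens), read by luminescence and calcium flux, with a stated time of 2 h (a higher number here means a weaker inhibitor, a lower number a stronger inhibitor), the lowest of the three numbers measured so far; compound 2 `Cc1ccc(S(=O)(=O)N2C=CNC(=O)[C@H]2CC(=O)N[C@@H]2CCc3ccccc32)cc1` gives 94.7 nM and compound 1 `Cc1ccc(S(=O)(=O)N2C=CNC(=O)[C@H]2CC(=O)N[C@H](C)c2ccccc2)cc1` gives 836 nM. The two steps onto compound 3, a 32-fold lower number from compound 1 to compound 3 (1.51 log units; beyond the scatter) and a 3.7-fold lower number from compound 2 to compound 3 (0.56 log units; beyond the scatter), both change the group on the amide-type nitrogen, as does an 8.8-fold lower number from compound 1 to compound 2 (0.95 log units; beyond the scatter). Compound 4 `Cc1ccc(S(=O)(=O)N2C=CNC(=O)[C@H]2CC(=O)NC2CCOCC2(C)C)cc1` differs from compound 3 by a group of 8 heavy atoms (7 carbon, 1 oxygen; one six-membered non-aromatic ring with 1 hetero atom) in place of a group of 7 heavy atoms (7 carbon; one six-membered non-aromatic ring of carbon only), on an amide-type nitrogen. Among the compounds with values here, no measured step exchanges a carbon-only ring for a ring holding an oxygen, so the earlier steps bear only indirectly: they show that this position moves the number across a wide span. A modest shift toward a higher number is expected here, a 2.1-fold higher number from compound 3 to compound 4 (0.33 log units; beyond the scatter). Compound 4 is estimated at 55 nM, within 15 nM to 200 nM.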

Compound 4, half-maximal inhibitory concentration: 25.2 nM
Beside the measured number, compound 4's estimate is 2.2-fold (0.34 log units) above it; low and high end bracket the measured number.
By their numbers in this assay, from the lowest: compounds 4 and 3 (each within the scatter of the next); then compound 2; then compound 1.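

On the amide-type nitrogen, the six-membered non-aromatic ring with 1 hetero atom, an oxygen, replaces the carbon-only ring of 2-methylcyclohexyl with no readable change, as a 1.0-fold lower number from compound 3 to compound 4 (0.01 log units; within the scatter) shows. The group entering here also stands well clear of the other two groups, with a 3.8-fold lower number from compound 2 to compound 4 (0.57 log units; beyond the scatter) and a 33-fold lower number from compound 1 to compound 4 (1.52 log units; beyond the scatter) in the same series. No measured evidence explains this result. Still open, as far as these compounds go, is how an amine nitrogen in place of the ring oxygen would read, and whether the number holds once the ring methyl groups are removed.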